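The source may hold more compounds than are shown below. What is called first, only, known or untested is meant among the compounds shown, and "the series" means these compounds.

Three compounds have been measured here, each in a functional assay on HT-29 cells (Homo sapiens) for antiproliferative activity, read by sulforhodamine B assay, with a stated time of 48 h; a lower number here means a stronger inhibitor, a higher number a weaker inhibitor:

Compound 1, `CCCCCC(=O)Nc1cccc(S(=O)(=O)Oc2ccccc2C(C)C)c1`, gives 19000 nM.
Compound 2, `CCC(=O)Nc1ccc(S(=O)(=O)Oc2ccccc2C(C)C)cc1`, gives 7400 nM.
Compound 3, `CCC(=O)Nc1ccc(S(=O)(=O)Oc2ccccc2I)cc1`, gives 11000 nM.

Compound 3 stands second highest of the three numbers. Going by the values given here, its nearest neighbour is compound 2, whose value sits lower by a margin that falls within the scatter of repeated measurement, and the only single-point step among the measured compounds is a 1.5-fold higher number from compound 2 to compound 3 (0.17 log units; within the scatter). Compound 1 lies furthest from compound 3, and even that gap stays within the scatter, so the three measured compounds are not separated from one another in this assay.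

Compound 4, `O=C(NCCCCl)Nc1ccc(S(=O)(=O)Oc2ccccc2I)cc1`, is not yet measured. It differs from compound 3 in one place: (3-chloropropyl)amino in place of ethyl on a carbonyl carbon. Among the compounds with values here, the single measured step concerns an iodo in place of an isopropyl on an aromatic carbon and does not touch the carbonyl side of the molecule, so no measured step bears on the change to compound 4. Within the data shown here, with no comparable step to lean on, the step of a 1.1-fold lower number from compound 3 to compound 4 (0.04 log units; within the scatter) is expected to stay within the scatter, and the estimate is wide. Compound 4 is therefore expected to give about 10000 nM, in a range from 3000 nM to 35000 nM.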

Compound 4, half-maximal inhibitory concentration: 9600 nM
The estimate for compound 4 lay 1.0-fold (0.02 log units) above the measured number; the range from low to high includes it.
By their numbers in this assay, from the lowest: compounds 2, 4, 3 and 1 (each within the scatter of the next, the first and the last beyond it).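

In this assay, going by these compounds alone, the step at the carbonyl carbon whose other neighbour is the amide-type nitrogen, with (3-chloropropyl)amino in place of ethyl, gives a 1.1-fold lower number from compound 3 to compound 4 (0.06 log units; within the scatter); no earlier step had touched this place. The exchange turns propanoylamino into ((3-chloropropyl)carbamoyl)amino, with a longer chain, a chlorine and one added hydrogen-bond donor, and even so it does not separate the two compounds in this assay, so this place admits that much change in the group without a readable difference. Nothing given here explains this result.

Going by these compounds, it remains open whether a propylamino group without the chlorine, a longer chain, or a chain carrying an amine or a carboxylic acid on this carbonyl carbon would also stay within the scatter of compound 3, or whether a group of that kind would move the number beyond it. Within the data shown here, it is equally open whether (3-chloropropyl)amino would read the same on a compound with isopropyl in place of iodo, since the only step that exchanges those two groups has ethyl on the carbonyl carbon.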